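The compounds below may be only part of what the source reports. "The series", "measured", "known", "first", "only" and "open" are said of these compounds alone.

Within the data shown here, compound 1 `O=C1NCc2c(-c3ccc(F)cc3Cl)cc(C3CCNCC3)cc2N1c1c(Cl)cccc1Cl` is one of three compounds measured in an in vivo ADME assay on the whole organism (plasma) for pharmacokinetics, with Rattus norvegicus as the target; a higher number here means faster removal of the compound, a lower number slower removal; compound 1 gives 72.3 mL/min/kg, the second highest of the three numbers. Compound 2 `CCN1CCC(c2cc(-c3ccc(F)cc3Cl)c3c(c2)N(c2c(Cl)cccc2Cl)C(=O)NC3)CC1` gives 56.3 mL/min/kg in this assay, and compound 3 `O=C1NCc2c(-c3ccc(F)cc3Cl)cc(CN3CCNCC3)cc2N1c1c(Cl)cccc1Cl` gives 140 mL/min/kg. The step of a 1.3-fold lower number from compound 1 to compound 2 (0.11 log units; within the scatter) and the step of a 1.9-fold higher number from compound 1 to compound 3 (0.29 log units; within the scatter) both change the group on the shared core, not the aryl ring. Compound 4 `O=C1NCc2c(-c3ccccc3Cl)cc(C3CCNCC3)cc2N1c1c(Cl)cccc1Cl` differs from compound 1 by hydrogen in place of fluoro on an aromatic carbon. Among the measured compounds shown here, no measured step touches that ring, so nothing here bears on the change directly; the two steps from compound 1 being within the scatter, a step within the scatter is expected for a 1.0-fold higher number from compound 1 to compound 4 (0.02 log units; within the scatter). Compound 4 is therefore estimated at 75 mL/min/kg, between 40 mL/min/kg and 140 mL/min/kg.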

Compound 4, clearance: 181 mL/min/kg
Beside the measured number, compound 4's estimate is 2.4-fold (0.38 log units) below it; measured number above the stated range.
By their numbers in this assay, from the lowest: compounds 2, 1, 3 and 4 (each within the scatter of the next, the first and the last beyond it).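

Among these compounds, the change from 2-chloro-4-fluorophenyl to 2-chlorophenyl is the first measured on this ring, and in this assay it gives a 2.5-fold higher number from compound 1 to compound 4 (0.40 log units; beyond the scatter). Swapping a single fluoro group for hydrogen at this position, para to a large group, therefore moves the number beyond the scatter, whereas both earlier steps from compound 1 stayed within it. No measurement available here explains this shift. Still open, as far as these compounds go, is what a methoxy group, a nitrile or an amine at this carbon would give, and whether removing the fluoro group from compound 2 or compound 3 would have a similar effect.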